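Piperazin-1-yl in Place of Vinyl on a Carbonyl Carbon

The compounds below may be only part of what the source reports. "The series", "measured", "known", "first", "only" and "open" are said of these compounds alone.

In a functional assay on LNCaP cells (Homo sapiens) for antiproliferative activity, read by MTT assay, with a stated time of 3 days (on this read-out lower numbers stand for stronger inhibition and higher numbers for weaker inhibition), compound 3 (`C=CC(=O)Nc1ccc(-c2cc(=O)c3c(O)cc(OC)c(OC(C)C)c3o2)cc1`) gives 15100 nM and compound 1 (`COc1cc(O)c2c(=O)cc(-c3ccc(NS(C)(=O)=O)cc3)oc2c1OC(C)C`) gives 15400 nM, the two standing level, as a 1.0-fold lower number from compound 1 to compound 3 (0.01 log units; within the scatter) shows. Compound 2 (`CCS(=O)(=O)Nc1ccc(-c2cc(=O)c3c(O)cc(OC)c(OC(C)C)c3o2)cc1`) gives 113000 nM, and the measured change to compound 3 is a 7.5-fold lower number from compound 2 to compound 3 (0.87 log units; beyond the scatter). Compound 4 (`COc1cc(O)c2c(=O)cc(-c3ccc(NC(=O)N4CCNCC4)cc3)oc2c1OC(C)C`) has piperazin-1-yl in place of vinyl on a carbonyl carbon. Among the measured compounds shown here, no measured step makes this exchange. Replacing the whole group on the nitrogen gave a 1.0-fold lower number from compound 1 to compound 3 (0.01 log units; within the scatter), yet a single methyl gave a 7.3-fold higher number from compound 1 to compound 2 (0.87 log units; beyond the scatter), so a shift of modest size cannot be excluded. Little net change beyond the scatter is expected, with a slight lean upward. The expected step is a 1.3-fold higher number from compound 3 to compound 4 (0.12 log units; within the scatter). Compound 4 is estimated at 20000 nM, within a range of 6000 nM to 70000 nM.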

Compound 4, half-maximal inhibitory concentration: 9500 nM
Estimate against measurement, compound 4: 2.1-fold (0.32 log units) above; the range from low to high includes it.
By their numbers in this assay, from the lowest: compounds 4, 3 and 1 (each within the scatter of the next); then compound 2.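

Exchanging vinyl for piperazin-1-yl on a carbonyl carbon, which brings in a six-membered non-aromatic ring with 2 hetero atoms, leaves this assay unmoved beyond the scatter: there is a 1.6-fold lower number from compound 3 to compound 4 (0.20 log units; within the scatter) and also a 1.6-fold lower number from compound 1 to compound 4 (0.21 log units; within the scatter) at the same level. Against the ethylsulfonyl group there is a 12-fold lower number from compound 2 to compound 4 (1.08 log units; beyond the scatter) and thus the widest gap so far, so three of the four groups on this nitrogen now sit together and only ethylsulfonyl stands apart. No evidence is at hand that would explain this result. On these data alone, whether morpholin-4-yl or dimethylamino on that carbonyl carbon would hold this level stays open.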